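Benzyl on the anilino nitrogen of compound 3

This account rests on a few compounds, and the source may have more. Where it says the series, first, only, none or still open, it means among the compounds named here.

Measured compounds:
Compound 1, `CNc1ccc(-c2cn3c(OC)cc(OC)nc3n2)cc1`; in a functional assay on HepG2 cells (Homo sapiens) for antiproliferative activity, read by MTT assay, with a stated time of 72 h (on this read-out higher numbers stand for weaker inhibition of growth and lower numbers for stronger inhibition of growth), compound 1 gives > 100000 nM, which is a limit of the assay.
Compound 2, `COc1cc(OC)n2cc(-c3ccc(N(Cc4ccccc4)Cc4ccccc4)cc3)nc2n1`; in this assay compound 2 gives > 100000 nM, again a limit.
Compound 3, `Cc1ccc2nc(-c3ccc(N)cc3)cn2c1`; in this assay compound 3 gives > 100000 nM, also a limit.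

Compound 3 therefore stands nowhere in particular on the numbers shown: it sits at the limit of the assay, and so do the two other measured compounds, as the limit of > 100000 nM in this assay, at which 3 of the 3 values shown sit, states. No two of these compounds differ in a single place, so no measured step exists to lean on.

Compound 4, `Cc1ccc2nc(-c3ccc(NCc4ccccc4)cc3)cn2c1`, is the next compound to be tested. It differs from compound 3 in one place only: benzyl in place of hydrogen on a nitrogen on an aromatic ring. Compounds 1 and 2 carry a different core and different substitution on the corresponding nitrogen, a methyl in one case and two benzyl groups in the other, and both sit at the limit, so nothing measured here shows that changing the substituent on this nitrogen moves the read-out.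

With only limits to go by, the step from compound 3 to compound 4 is expected to be no change that can be told apart from the scatter, a step that the limit leaves unreadable from compound 3 to compound 4, and the result is expected most likely to be another limit. For compound 4 the estimate in this assay is 150000 nM, with a range from 20000 nM to 1000000 nM.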

Compound 4, concentration for 50% growth inhibition: > 100000 nM
Compound 4 was reported as a limit; the forecaster's own chance of this, stated with the estimate: 70%; the middle value lies beyond the limit too.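

No step can be read from compound 3 to compound 4, since both results are limits of the assay: the limit of > 100000 nM in this assay, at which 4 of the 4 values shown sit.

The compounds shown leave open whether benzyl in place of hydrogen on a nitrogen on an aromatic ring changes the read-out in this assay at all, as none of them gives a value inside the measurable range.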